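The source may report more compounds than this note shows. Statements on the series, on what has been measured and on what is new or still open speak of the compounds shown alone.

In an assay on isolated protein for binding affinity to adenosine receptor A1 (Bos taurus) (on this read-out lower numbers stand for stronger inhibition and higher numbers for weaker inhibition), the measured compounds are:

compound 1 `CCCCCCNc1nc(-c2ccccc2)nc2c1nnn2Cc1ccccc1` — 13200000 nM
compound 2 `CNc1nc(-c2ccccc2)nc2c1nnn2Cc1ccccc1` — 353000000 nM
compound 3 `c1ccc(Cn2nnc3c(NC4CCCC4)nc(-c4ccccc4)nc32)cc1` — 11000000 nM

Compound 3 has the lowest number of the three, but its gap to compound 1 is within the scatter (a 1.2-fold lower number from compound 1 to compound 3 (0.08 log units; within the scatter)), so the two cannot be ordered; only compound 2 stands clearly apart (a 32-fold lower number from compound 2 to compound 3 (1.51 log units; beyond the scatter)).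

Compound 4 `c1ccc(Cn2nnc3c(NC4CCC4)nc(-c4ccccc4)nc32)cc1` differs from compound 3 by cyclobutyl in place of cyclopentyl on a nitrogen on an aromatic ring. Going by the values given here, two steps bear on this. Replacing hexyl with cyclopentyl left the number unchanged (a 1.2-fold lower number from compound 1 to compound 3 (0.08 log units; within the scatter)), whereas the methyl analogue is far weaker (a 32-fold lower number from compound 2 to compound 3 (1.51 log units; beyond the scatter)). Cyclobutyl keeps a ring on the nitrogen, so a step within the scatter, or a modest rise, is expected rather than a loss on the scale seen for compound 2.

Compound 4 is therefore estimated at 16000000 nM, with a range of 5000000 nM to 50000000 nM, an expected step of a 1.5-fold higher number from compound 3 to compound 4 (0.16 log units; within the scatter).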

Compound 4, inhibition constant: 5000000 nM
The estimate for compound 4 lay 3.2-fold (0.51 log units) above the measured number; the measured number falls inside the stated range.
By their numbers in this assay, from the lowest: compound 4; then compounds 3 and 1 (each within the scatter of the next); then compound 2.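

In this assay the size of the ring on the nitrogen now registers: cyclobutyl in place of cyclopentyl gives a step beyond the scatter (a 2.2-fold lower number from compound 3 to compound 4 (0.34 log units; beyond the scatter)). Compound 4 also separates from the hexyl analogue (a 2.6-fold lower number from compound 1 to compound 4 (0.42 log units; beyond the scatter)), which compound 3 did not, and it stands far from the methyl analogue (a 71-fold lower number from compound 2 to compound 4 (1.85 log units; beyond the scatter)). No measurement on hand accounts for these steps.

Going by these compounds, whether cyclopropyl would continue the direction seen from cyclopentyl to cyclobutyl remains open. So does the effect of a hydroxyl or an amine on the cyclobutyl ring.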